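The source may report more compounds than this note shows. Statements on the series, on what has been measured and on what is new or still open speak of the compounds shown alone.

Compound 1 `Cn1c(-c2ccc(NC(=O)CSc3nc4ccccc4s3)cc2)nc(-c2ccccc2)c1-c1ccccc1`, compound 2 `Cn1nnnc1SCC(=O)Nc1ccc(-c2nc(-c3ccccc3)c(-c3ccccc3)n2C)cc1` and compound 3 `Cc1nnc(SCC(=O)Nc2ccc(-c3nc(-c4ccccc4)c(-c4ccccc4)n3C)cc2)s1` share one core and differ only in the group carried on the sulfur. In a functional assay on MCF7 cells (Homo sapiens) for cytotoxicity, read by MTT assay, with a stated time of 24 h, tested at 1.6 ug/mL (a higher number here means a stronger effect of the compound at the concentration tested, a lower number a weaker effect), compound 1 gives 2.1%, compound 2 gives 34.3% and compound 3 gives 37.5%. Compound 3 stands at the top of the three numbers, yet its gap to compound 2 lies within the scatter, so those two are not distinguished; only the gap to compound 1 is real. The steps of a number 32.2 percentage points higher from compound 1 to compound 2 (beyond the scatter) and a number 35.4 percentage points higher from compound 1 to compound 3 (beyond the scatter) show that the group at this place carries much of the read-out, whereas a number 3.2 percentage points higher from compound 2 to compound 3 (within the scatter) shows that the exchange between compound 2 and compound 3 changed little. Compound 4 `CN(C)/C=C/N1CCN(CC(=O)Nc2ccc(-c3nc(-c4ccccc4)c(-c4ccccc4)n3C)cc2)CC1`, not yet measured, arises from compound 3 by the change (4-(2-(dimethylamino)ethenyl)piperazin-1-yl in place of (5-methyl-1,3,4-thiadiazol-2-yl)sulfanyl on a saturated chain carbon bound to a carbonyl carbon). For the measured compounds named here, no measured step removes the sulfanyl link itself, so the data give no direct guide, and the wide swings seen from compound 1 warn that the read-out may move far in either direction. Compound 4 is estimated at 30%, within 5% to 60%. The step of a number 7.5 percentage points lower from compound 3 to compound 4 (within the scatter) is expected to stay within the scatter, with low confidence.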

Compound 4, a percentage reported as activity, at one concentration (the size of the read-out at that concentration, not a potency): 1.9%
The estimate for compound 4 lay 28.1 percentage points above the measured number; the whole stated range lies above it.
By their numbers in this assay, from the lowest: compounds 4 and 1 (each within the scatter of the next); then compounds 2 and 3 (each within the scatter of the next).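

On a saturated chain carbon bound to a carbonyl carbon, putting 4-(2-(dimethylamino)ethenyl)piperazin-1-yl in place of the sulfanyl groups gives a number 35.6 percentage points lower from compound 3 to compound 4 (beyond the scatter) and a number 32.4 percentage points lower from compound 2 to compound 4 (beyond the scatter) and thus shows that the read-out can also be lost when the whole sulfur-linked group is exchanged, not only the group on the sulfur. With a number 0.2 percentage points lower from compound 1 to compound 4 (within the scatter) this group is not distinguished from (1,3-benzothiazol-2-yl)sulfanyl, so two very different groups share the same low read-out, and the sulfur link alone does not secure a high one. Nothing measured here accounts for the loss.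

The compounds shown leave open whether the loss goes with the piperazine ring, the dimethylamino ethenyl arm or the absence of sulfur, as all three change together. An unsubstituted piperazin-1-yl, a morpholine or a simple dimethylamino group on the same chain carbon would begin to separate these.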